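Methoxy groups on the shared core: working notes

The compounds below may be only part of what the source reports. "The series", "measured", "known", "first", "only" and "open" are said of these compounds alone.

Measured in a functional assay on MCF7 cells (Homo sapiens) for inhibition, read by MTT assay, with a stated time of 72 h; on this read-out higher numbers stand for weaker inhibition and lower numbers for stronger inhibition:
compound 1 `C=C(Br)C(=O)Nc1cccc(/C=C/C(=O)Nc2ccccc2)c1`: 27300 nM
compound 2 `C=C(Br)C(=O)Nc1cccc(/C=C/C(=O)Nc2ccc(OC)cc2)c1`: 2500 nM
compound 3 `C=C(Br)C(=O)Nc1cccc(/C=C/C(=O)Nc2cc(OC)cc(OC)c2)c1`: 3000 nM

Within the data shown here, the one counted change so far is methoxy in place of hydrogen on an aromatic carbon, which gave an 11-fold lower number from compound 1 to compound 2 (1.04 log units; beyond the scatter). How the core of compound 3 differs from that of compound 1 is not broken down here; the values of compound 2 and compound 3 sit within the scatter of each other. Compound 4 `C=C(Br)C(=O)Nc1cccc(/C=C/C(=O)Nc2cc(OC)c(OC)c(OC)c2)c1` awaits this assay. It differs from compound 3 by methoxy in place of hydrogen on an aromatic carbon, the same kind of change as from compound 1 to compound 2, but here the place is ortho to two methoxy groups (2 heavy atoms each) and para to a large group, not para to a large group alone. Because compound 3 with 3000 nM gained nothing beyond scatter over compound 2, a small step is expected, a 1.2-fold lower number from compound 3 to compound 4 (0.08 log units; within the scatter). Compound 4 is estimated at 2500 nM, between 800 nM and 8000 nM.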

Compound 4, half-maximal inhibitory concentration: 1800 nM
Compound 4: the middle estimate sits 1.4-fold (0.14 log units) above what was measured; measured number inside the range.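

In this assay methoxy in place of hydrogen on an aromatic carbon gives a 1.7-fold lower number from compound 3 to compound 4 (0.22 log units; within the scatter) and does not keep the size it had on the core of compound 1: the same change on two cores in this assay, an 11-fold lower number (1.04 log units; beyond the scatter) from compound 1 to compound 2 and a 1.7-fold lower number (0.22 log units; within the scatter) from compound 3 to compound 4, 6.6-fold (0.82 log units) apart, beyond the scatter of two such steps.

In this series, the step seen on one core cannot be assumed at the same size on another. Among these compounds, with only two cores compared, these steps do not show which difference between the cores goes with the gap, nor how the change behaves on any further core.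

Still open, from the compounds shown here alone, is whether a hydroxy group, fluorine or an amine in place of that hydrogen would follow methoxy. Going by these compounds, a longer chain such as ethoxy is equally open.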